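The compounds below may be only part of what the source reports. "The series", "measured", "known", "first", "only" and "open" are said of these compounds alone.

Measured so far in an ADME assay on microsomes from liver (Mus musculus) for metabolic stability, read by LC-MS, using NADPH, tested at 1 uM; a lower number here means that the compound disappears faster, a higher number that the compound lasts longer:

- Compound 1 `N#Cc1cnc(NC(=O)CCCOc2ccccc2)s1`: 0.25 h
- Compound 2 `CC(C)c1cnc(NC(=O)CCCOc2ccccc2)s1`: 0.0333 h

Of these two half-lives, compound 2 has the lower, at 0.0333 h, so it is the one that disappears faster. Among the compounds with values here, the only measured step is a 7.5-fold lower number from compound 1 to compound 2 (0.88 log units; beyond the scatter), with isopropyl in place of cyano on an aromatic carbon.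

Compound 3 `Cc1cnc(NC(=O)CCCOc2ccccc2)s1` keeps the shared core and changes the same place again: methyl in place of isopropyl on an aromatic carbon. In plain terms, this is methyl in place of isopropyl.

Within the data shown here, no measured step covers this exact swap, and no measured compound carries methyl there, so the evidence is thin. The step to compound 2 shows that this place can matter, since it gave a 7.5-fold lower number from compound 1 to compound 2 (0.88 log units; beyond the scatter). Compound 2 also sits at the low end of the two values, at 0.0333 h, which leaves more room for a rise than for a fall. A modest rise in this assay is therefore expected, though it may not reach the value of compound 1. The expected change is a 2.4-fold higher number from compound 2 to compound 3 (0.38 log units; beyond the scatter). For compound 3 the expected half-life is 0.08 h, with an estimated range of 0.03 h to 0.22 h.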

Compound 3, half-life: 0.0333 h
Compound 3: the middle estimate sits 2.4-fold (0.38 log units) above what was measured; measured number inside the range.
By their numbers in this assay, from the lowest: compounds 2 and 3 (each within the scatter of the next); then compound 1.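

In this assay, replacing isopropyl with methyl on this aromatic carbon gives no change at the digits printed from compound 2 to compound 3 (within the scatter), so these two groups cannot be told apart at this place. Replacing the nitrile of compound 1 with methyl gives a 7.5-fold lower number from compound 1 to compound 3 (0.88 log units; beyond the scatter), which matches the earlier step from nitrile to isopropyl, so that earlier drop is not particular to isopropyl: compound 2 and compound 3 stand together, with compound 1 apart from both. No measurement here offers an explanation for this result.

The compounds shown leave open whether the nitrile is unusual or whether other groups at this place, such as a chlorine atom, a trifluoromethyl group or a methyl ester, would stand with compound 1 or with compound 2 and compound 3. They also leave open how changes elsewhere would affect the half-life, for example replacing the phenyl ring at the far end of the chain with a pyridine, as the rest of the molecule is the same in all three compounds.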